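The compounds below may be only part of what the source reports. "The series", "measured", "known", "first", "only" and "open" are said of these compounds alone.

Values so far in a functional assay on WiDr cells (Homo sapiens) for antiproliferative activity, read by sulforhodamine B assay, with a stated time of 48 h; on this read-out lower numbers stand for stronger inhibition of growth and higher numbers for weaker inhibition of growth:
- Compound 1 `CC(C)(C)[Si](C)(C)O[C@@H]1CCCO[C@@H]1CO` gives > 100000 nM, which is a limit and not a number
- Compound 2 `COC(=O)/C=C\[C@H]1OCCC[C@H]1O[Si](C)(C)C(C)(C)C` gives 38000 nM
- Compound 3 `COC(=O)/C=C/[C@H]1OCCC[C@@H]1O[Si](C)(C)C(C)(C)C` gives 84000 nM

Compound 2 holds the lowest of the two actual numbers in the series. The nearest number comes with a 2.2-fold higher number from compound 2 to compound 3 (0.34 log units; beyond the scatter), and that pair is set apart only by the fact that compounds 2 and 3 differ only in the configuration as drawn.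

Compound 4 `C=C[C@H]1OCCC[C@H]1O[Si](C)(C)C(C)(C)C` is the next case, with vinyl in place of 2-(methoxycarbonyl)ethenyl on a saturated ring carbon.

The measured step that bears most directly on this change is an at least 2.6-fold lower number from compound 1 to compound 2 (0.42 log units; beyond the scatter), where 2-(methoxycarbonyl)ethenyl took the place of hydroxymethyl on a saturated ring carbon. Its size is bounded only by the limit of > 100000 nM in this assay, at which 1 of the 3 values shown sits. The configuration step involves no change of group and serves only as a guide to how large a modest step is in this series. For the measured compounds named here, no measured step brings in vinyl, so the read-across is loose.

A modest move towards weaker inhibition of growth in this assay is expected, and the expected step is a 1.6-fold higher number from compound 2 to compound 4 (0.20 log units; within the scatter). For compound 4 the estimate is 60000 nM, with an expected range of 28000 nM to 100000 nM.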

Compound 4, concentration for 50% growth inhibition: > 100000 nM
Compound 4 gave a limit, no number (the forecaster's own chance of this, stated with the estimate: 25%); middle value at least 1.6-fold (0.22 log units) away from the limit.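

In this assay compound 4 gives > 100000 nM, which is a limit of the assay and not a number. On the saturated ring carbon next to the ring oxygen, cutting 2-(methoxycarbonyl)ethenyl back to vinyl gives an at least 2.6-fold higher number from compound 2 to compound 4 (0.42 log units; beyond the scatter), so the double bond that vinyl keeps on this carbon is not enough to hold the growth inhibition seen with compound 2, and in this pair the measurable value goes with the presence of the methoxycarbonyl part. The step between the hydroxymethyl of compound 1 and the vinyl of compound 4 cannot be read, and the two groups cannot be ranked against each other at this position: the limit of > 100000 nM in this assay, at which 2 of the 4 values shown sit.

The compounds shown leave open whether the methoxycarbonyl part needs the double bond that links it to the ring, which a saturated 2-(methoxycarbonyl)ethyl chain at the same carbon would test. They also leave open whether the methyl ester itself matters, or whether a carboxylic acid, a primary amide or a nitrile in its place would give a value of similar size.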